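This account rests on a few compounds, and the source may have more. Where it says the series, first, only, none or still open, it means among the compounds named here.

Compound 1, `COc1ccc(S(C)(=O)=O)c(NCC2=NCCN2)c1`, in an assay on CHO cells for binding affinity to Alpha-2B adrenergic receptor (Homo sapiens), read by radioligand binding (on this read-out lower numbers stand for stronger inhibition and higher numbers for weaker inhibition), gives < 6310 nM, which is a limit of the assay and not a number.
Compound 2, `COc1ccc(SC)c(NCC2=NCCN2)c1`, in this assay gives < 6310 nM, again a limit rather than a number.

Compound 1 therefore stands only at a limit; both values shown sit at the limit of < 6310 nM in this assay, at which 2 of the 2 values shown sit. Going by the values given here, the single measured step, a step that the two limits leave unreadable from compound 1 to compound 2, has no readable size, since both of its ends are limits. Compound 3, `CS(=O)(=O)c1ccc(C(F)(F)F)cc1NCC1=NCCN1`, has not yet been measured; it differs from compound 1 by trifluoromethyl in place of methoxy on an aromatic carbon. Among the compounds with values here, no measured step bears on this change, and the one step that exists gives no size at all. The expectation for compound 3 thus rests on the limit alone, and the expected step, a step that the limit leaves unreadable from compound 1 to compound 3, is taken as no more than the scatter in either direction. Compound 3 is estimated in this assay at 1000 nM, with a range from 100 nM to 6000 nM.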

Compound 3, inhibition constant: < 6310 nM
Compound 3 was reported as a limit; the forecaster's own chance of this, stated with the estimate: 55%; the middle value does not contradict the limit.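

No step can be read between compound 1 and compound 3, since each stands only at a limit of the assay: the limit of < 6310 nM in this assay, at which 3 of the 3 values shown sit.
The compounds shown leave open what their actual values are in this assay and how far trifluoromethyl in place of methoxy on an aromatic carbon moves them.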